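Methyl on the ring nitrogen: compound 1 to compound 4

A few compounds are considered here, and "the series" means these few. Any claim that something is new, unique, unknown or untested is made for them only; others in the source may bear on it.

Within the data shown here, in an in vivo ADME assay on the whole organism for pharmacokinetics, with Rattus norvegicus as the target, at a dose of 0.5 mg/kg by the intravenous route (on this read-out lower numbers stand for narrower distribution and higher numbers for wider distribution into tissues), compound 1 `CC(=O)Nc1cc(-c2c(Nc3cc[nH]n3)nc3cccnn23)nc(C)n1` gives 6.3 L/kg, the highest of the three numbers measured so far. Compound 3 `CNc1cc(-c2c(Nc3cc[nH]n3)nc3cccnn23)nc(C)n1` gives 1.3 L/kg in this assay, and compound 2 `Cc1nccc(-c2c(Nc3cc[nH]n3)nc3cccnn23)n1` gives 0.62 L/kg. The three measured steps all change the substituent on the shared core, away from the (1H-pyrazol-3-yl)amino group: a 10-fold lower number from compound 1 to compound 2 (1.01 log units; beyond the scatter), a 4.8-fold lower number from compound 1 to compound 3 (0.69 log units; beyond the scatter) and a 2.1-fold higher number from compound 2 to compound 3 (0.32 log units; beyond the scatter). Compound 4 `CC(=O)Nc1cc(-c2c(Nc3ccn(C)n3)nc3cccnn23)nc(C)n1` differs from compound 1 in a different place: methyl in place of hydrogen on an aromatic nitrogen. Among the measured compounds shown here, no measured pair differs at this aromatic nitrogen, so none of the three steps bears directly on the change; they show only that the number for compound 1 moves widely when the acetamido group is altered, while the (1H-pyrazol-3-yl)amino group is the same in compound 1, compound 2 and compound 3. For the measured compounds named here, with no comparable step to draw on, the change from compound 1 to compound 4 is expected to stay within the scatter of this assay, with a wide range allowed. The starting point is compound 1, because compound 1 gives 6.3 L/kg. Compound 4 is therefore expected at 5 L/kg, with a range of 2 L/kg to 12 L/kg, the expected step being a 1.3-fold lower number from compound 1 to compound 4 (0.10 log units; within the scatter).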

Compound 4, volume of distribution at steady state: 0.8 L/kg
For compound 4 the middle estimate is 6.3-fold (0.80 log units) above the measured one; measured number below the stated range.
By their numbers in this assay, from the lowest: compounds 2, 4 and 3 (each within the scatter of the next, the first and the last beyond it); then compound 1.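

In this assay, among these compounds, the (1H-pyrazol-3-yl)amino group, unchanged across the earlier compounds, turns out to be a second place where the number responds strongly: methyl in place of hydrogen on its aromatic nitrogen gives a 7.9-fold lower number from compound 1 to compound 4 (0.90 log units; beyond the scatter). This single methyl, one heavy atom, produces a step of comparable size to those at the acetamido group, a 4.8-fold lower number from compound 1 to compound 3 (0.69 log units; beyond the scatter) and a 10-fold lower number from compound 1 to compound 2 (1.01 log units; beyond the scatter), so the high number of compound 1 is not tied to the acetamido group alone. Nothing available here accounts for the size of the step at the ring nitrogen.

From the compounds shown here alone, it remains open whether the methyl on this aromatic nitrogen would lower the number to a similar extent in compound 2 and compound 3, where the acetamido group is absent. Going by these compounds, it is equally open whether the response is particular to methyl or extends to a longer chain such as ethyl, or to a chain ending in a hydroxyl group or an amine, on the same nitrogen.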